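Adding a cyclopentyl group to a potent adenosine receptor ligand

The source may report more compounds than this note shows. Statements on the series, on what has been measured and on what is new or still open speak of the compounds shown alone.

Compound 1 `CNC(=O)[C@H]1O[C@@H](n2cnc3c(N)nc(Cl)nc32)[C@H](O)[C@@H]1O` is the stronger of the two measured compounds: in an assay on CHO cells for displacement of a labelled ligand from adenosine receptor A3 (Homo sapiens) (a higher number here means a weaker inhibitor, a lower number a stronger inhibitor), compound 1 gives 0.398 nM, while compound 2 `O=C(NC1CC1)[C@H]1O[C@@H](n2cnc3c(NC4CC4)nc(Cl)nc32)[C@H](O)[C@@H]1O` gives 5.62 nM, a gap well beyond the usual scatter. Compound 3 `CNC(=O)[C@H]1O[C@@H](n2cnc3c(NC4CCCC4)nc(Cl)nc32)[C@H](O)[C@@H]1O` differs from compound 1 by one change, (cyclopentyl in place of hydrogen on a nitrogen on an aromatic ring). Going by the values given here, no measured pair isolates this change, so the step can only be anticipated. The step from compound 1 to compound 3 is expected to raise the number moderately, a 7.5-fold higher number from compound 1 to compound 3 (0.88 log units; beyond the scatter). Compound 3 is therefore estimated at 3 nM, with a plausible range from 0.6 nM to 15 nM.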

Compound 3, inhibition constant: 4.27 nM
Beside the measured number, compound 3's estimate is 1.4-fold (0.15 log units) below it, and the stated range covers the measured number.
By their numbers in this assay, from the lowest: compound 1; then compounds 3 and 2 (each within the scatter of the next).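

In this assay, going by these compounds alone, putting cyclopentyl in place of hydrogen on this nitrogen gives an 11-fold higher number from compound 1 to compound 3 (1.03 log units; beyond the scatter), a large loss that isolates this single change for the first time. The change is costly but does not abolish activity, as compound 3 still gives 4.27 nM. Nothing available explains the size of this loss.

From the compounds shown here alone, whether a methyl, a benzyl or a straight butyl group on the same nitrogen would cost more or less remains open. So does whether the step would be the same on a different core.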